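The source may report more compounds than this note shows. Statements on the series, on what has been measured and on what is new or still open speak of the compounds shown alone.

Compound 2 `COc1cc(NC(=O)c2ccc(C#N)cc2)ccc1NS(C)(=O)=O` is tested for cytotoxicity in an ADME assay on RAW264.7 cells (Mus musculus) for cytotoxicity, read by MTT assay, with a stated time of 48 h; on this read-out lower numbers stand for stronger inhibition and higher numbers for weaker inhibition. On these data alone, compound 2 gives > 250000 nM, which is a limit of the assay and not a number, so its exact standing is unknown. Going by the values given here, the only firm number in this small set comes from compound 1 `CCS(=O)(=O)Nc1ccc(NC(=O)c2ccc(C#N)cc2)cc1C`, which gives 109000 nM.

Compound 3 `CCS(=O)(=O)Nc1ccc(NC(=O)c2ccc(C#N)cc2)cc1OC` is made from compound 2 by one small edit, methyl in place of hydrogen on a saturated chain carbon bound to a sulfonyl sulfur: methylsulfonyl becomes ethylsulfonyl. Among the compounds with values here, no measured pair shows what this edit does, so any forecast is uncertain. A modest move toward lower numbers in this assay is expected, though the result may stay within the scatter or again reach the limit. That expectation leans on compound 1 at 109000 nM. The estimated change is an at least 1.4-fold lower number from compound 2 to compound 3 (0.16 log units; that floor lies within the scatter). For compound 3 the expected value is 170000 nM, with an estimated range from 90000 nM to 320000 nM.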

Compound 3, half-maximal inhibitory concentration: 66400 nM
For compound 3 the middle estimate is 2.6-fold (0.41 log units) above the measured one; the measured number lies below the stated range.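

In this assay, going by these compounds alone, the step from methylsulfonyl to ethylsulfonyl can now be read for the first time, as an at least 3.7-fold lower number from compound 2 to compound 3 (0.57 log units; beyond the scatter), so adding one methyl on the saturated chain carbon bound to the sulfonyl sulfur moves the number clearly downward. Compound 2 stands at a limit of the assay and not at a number, so this step gives only a floor for the change: the limit of > 250000 nM in this assay, at which 1 of the 3 values shown sits.

The second comparison, methoxy in place of methyl on an aromatic carbon, gives a 1.6-fold lower number from compound 1 to compound 3 (0.22 log units; within the scatter), so compound 1 and compound 3 cannot be told apart here.

On these data alone, it remains open whether a longer chain, such as propylsulfonyl, would continue this downward move, or whether a chain ending in an amine would reverse it. A single pair also cannot show whether the same methyl edit would have a similar effect on the core of compound 1.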